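This account rests on a few compounds, and the source may have more. Where it says the series, first, only, none or still open, it means among the compounds named here.

Values measured in a functional assay on DU-145 cells (Homo sapiens) for cytotoxicity, read by trypan blue exclusion, with a stated time of 96 h (a higher number here means a weaker inhibitor, a lower number a stronger inhibitor), so far
- compound 1 `COc1cc(OC)c(/C=C/S(=O)(=O)Cc2ccc(F)c(N)c2)c(OC)c1` gives 2500 nM
- compound 2 `COc1ccc(CS(=O)(=O)/C=C/c2c(OC)cc(OC)cc2OC)c(N)c1` gives 25 nM
- compound 3 `COc1cc(OC)c(/C=C/S(=O)(=O)Cc2ccc(Br)c(N)c2)c(OC)c1` gives 750 nM

Compound 3 holds the middle place among these three numbers. It is a moderate distance from its nearest neighbour, a 3.3-fold lower number from compound 1 to compound 3 (0.52 log units; beyond the scatter), and much further from the lowest number, a 30-fold higher number from compound 2 to compound 3 (1.48 log units; beyond the scatter).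

The next molecule, compound 4 `COc1cc(OC)c(/C=C/S(=O)(=O)Cc2ccc(Cl)cc2N)c(OC)c1`, has not yet been measured. It differs from compound 3 by 2-amino-4-chlorophenyl in place of 3-amino-4-bromophenyl on a saturated chain carbon bound to a sulfonyl sulfur.

Among the compounds with values here, two measured steps bear on this change. The swap of fluoro for bromo was modest, as the step to compound 3 shows. Within the data shown here, the change of the whole ring group was far larger, seen in a 100-fold lower number from compound 1 to compound 2 (2.00 log units; beyond the scatter), and compound 2 is the only measured compound carrying a 2-amino-4-substituted group. Among the measured compounds shown here, no measured compound pairs that arrangement with a halogen, so how much of the large step would carry over is unknown.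

For the measured compounds named here, a step down of moderate size is therefore expected, smaller than the one seen with compound 2. The estimated step is a 5.0-fold lower number from compound 3 to compound 4 (0.70 log units; beyond the scatter) in this assay as a working expectation. Compound 4 is estimated at 150 nM with an expected range of 30 nM to 800 nM as its bounds.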

Compound 4, half-maximal inhibitory concentration: 2500 nM
For compound 4 the middle estimate is 17-fold (1.22 log units) below the measured one; the measured number lies above the stated range.
By their numbers in this assay, from the lowest: compound 2; then compound 3; then compounds 1 and 4 (each within the scatter of the next).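

In this assay, the 2-amino-4-substituted ring does not give a low number by itself: exchanging methoxy for chloro on that ring gives the largest step seen with this change (a 100-fold higher number from compound 2 to compound 4 (2.00 log units; beyond the scatter)), so among the compounds shown, only compound 2, with its methoxy, reaches the low range. Compared with the two other halogen compounds, compound 4 gains nothing from its ring, with a 3.3-fold higher number from compound 3 to compound 4 (0.52 log units; beyond the scatter) and no change at the digits printed from compound 1 to compound 4 (within the scatter), although both of these swaps alter the halogen and the ring arrangement together, so neither change can be read alone. No measurement here explains why chloro and methoxy differ so sharply at this place on the ring.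

As far as these compounds go, it remains open whether the low number needs methoxy specifically, since an ethoxy, a hydroxyl or a methyl in place of the chloro of compound 4 would show how narrow the requirement is. A 3-amino-4-methoxyphenyl group on the same saturated chain carbon bound to a sulfonyl sulfur would also show whether methoxy still gives a low number with the other amino arrangement.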